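Aryl hydrazone variation on the shared core: compound 4

The compounds below may be only part of what the source reports. "The series", "measured", "known", "first", "only" and "open" are said of these compounds alone.

Compound 1 `Cn1c(=O)c(=O)n(C2CCCC2)c2nc(N/N=C/c3ccccc3)ncc21` carries an unsubstituted phenyl on the carbon with a double bond to nitrogen. In a functional assay on A549 cells (Homo sapiens) for antiproliferative activity, read by MTT assay (on this read-out lower numbers stand for stronger inhibition and higher numbers for weaker inhibition), compound 1 reaches only the assay limit, > 100000 nM. Compound 2 `Cn1c(=O)c(=O)n(C2CCCC2)c2nc(N/N=C/c3cccc(Cl)c3Cl)ncc21` bears 2,3-dichlorophenyl there, and in this assay compound 2 gives 39100 nM. Compound 3 `Cc1ccc(/C=N/Nc2ncc3c(n2)n(C2CCCC2)c(=O)c(=O)n3C)cc1C` bears 3,4-dimethylphenyl, and in this assay compound 3 gives 30200 nM. Each substituted aryl brings a step beyond the scatter against the parent: an at least 2.5-fold lower number from compound 1 to compound 2 (0.40 log units; beyond the scatter) and an at least 3.3-fold lower number from compound 1 to compound 3 (0.51 log units; beyond the scatter). Between the two substituted compounds the step is a 1.3-fold lower number from compound 2 to compound 3 (0.11 log units; within the scatter), within the scatter. Compound 2 therefore holds the higher of the two measured numbers, with compound 3 nearest. The remaining value is a limit (the limit of > 100000 nM in this assay, at which 1 of the 3 values shown sits).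

Compound 4 `Cn1c(=O)c(=O)n(C2CCCC2)c2nc(N/N=C/c3cc([N+](=O)[O-])ccc3Cl)ncc21` is the next variation: 2-chloro-5-nitrophenyl in place of 2,3-dichlorophenyl on a carbon with a double bond to nitrogen. The steps from compound 1 show that both substituted aryls lowered the number modestly, while the exchange between compound 2 and compound 3 stayed within the scatter. For compound 4 the expected step is a 1.2-fold lower number from compound 2 to compound 4 (0.07 log units; within the scatter), nothing beyond the scatter. Compound 4 is estimated at 33000 nM in this assay, ranging from 11000 nM to 100000 nM.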

Compound 4, half-maximal inhibitory concentration: 8780 nM
Estimate against measurement, compound 4: 3.8-fold (0.58 log units) above; the whole stated range lies above it.
By their numbers in this assay, from the lowest: compound 4; then compounds 3 and 2 (each within the scatter of the next). At a limit, above all of these: compound 1.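

In this assay, within the data shown here, exchanges among substituted aryls on the carbon with a double bond to nitrogen had so far stayed within the scatter; 2-chloro-5-nitrophenyl now gives a 4.5-fold lower number from compound 2 to compound 4 (0.65 log units; beyond the scatter), and also a 3.4-fold lower number from compound 3 to compound 4 (0.54 log units; beyond the scatter). This position can therefore separate substituted aryls, and the entering group carries hydrogen-bond acceptors where 2,3-dichlorophenyl has none, although nothing here ties the step to them. Compound 1 is held at a limit, so the step from the unsubstituted phenyl reads an at least 11-fold lower number from compound 1 to compound 4 (1.05 log units; beyond the scatter) and stays open-ended on one side: the limit of > 100000 nM in this assay, at which 1 of the 4 values shown sits.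

The compounds shown do not separate the nitro group from the chlorine that stays with it. From the compounds shown here alone, how an amine, a nitrile or a carboxylic acid in place of the nitro group would read in this assay remains open.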